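The source may report more compounds than this note shows. Statements on the series, on what has been measured and on what is new or still open speak of the compounds shown alone.

In an ADME assay on Vero cells (Chlorocebus sabaeus) for cytotoxicity, read by MTT assay, with a stated time of 72 h (a lower number here means that less compound is tolerated, a higher number that more compound is tolerated), compound 3 `CCOc1ccc(C(=O)/C=C/c2ccc(C(=O)Nc3cccc(-c4cc(C(=O)OC)no4)c3)cc2)cc1` gives > 40 ug/mL, which is a limit of the assay rather than a number. Compound 1 `COC(=O)c1cc(-c2cccc(NC(=O)c3ccc(/C=C/C(=O)c4cccc(F)c4)cc3)c2)on1` gives > 40 ug/mL, also a limit. Compound 2 `CCCOc1ccc(C(=O)/C=C/c2ccc(C(=O)Nc3cccc(-c4cc(C(=O)OC)no4)c3)cc2)cc1` gives > 40 ug/mL, a limit as well. Hence (the limit of > 40 ug/mL in this assay, at which 3 of the 3 values shown sit). The steps a step that the two limits leave unreadable from compound 1 to compound 3, a step that the two limits leave unreadable from compound 1 to compound 2 and a step that the two limits leave unreadable from compound 2 to compound 3 have no readable size. Compound 4 `COC(=O)c1cc(-c2cccc(NC(=O)c3ccc(/C=C/C(=O)c4cccc(Cl)c4)cc3)c2)on1` differs from compound 3 by 3-chlorophenyl in place of 4-ethoxyphenyl on a carbonyl carbon. The nearest comparison is compound 1, which carries a 3-fluorophenyl on that carbonyl carbon and sits at the same limit. With no readable step among the measured compounds, no change beyond the scatter is expected in this assay, and the estimated step that the limit leaves unreadable from compound 3 to compound 4 is small. Compound 4 is expected to give 55 ug/mL, between 30 ug/mL and 120 ug/mL.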

Compound 4, half-maximal cytotoxic concentration: > 2.5 ug/mL
Compound 4: a limit, no number; the forecaster's own chance of this, stated with the estimate: 85%; the middle value lies beyond the limit too.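

For the compounds shown here, compound 1, compound 2, compound 3 and compound 4 all stand at limits in this assay, and no step to compound 4 can be read. As far as these compounds go, the actual half-maximal cytotoxic concentration of each of these four compounds remains open.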